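Methoxy on the aryl ring: expected effect on growth inhibition

The compounds below may be only part of what the source reports. "The series", "measured", "known", "first", "only" and "open" are said of these compounds alone.

Compound 1 `CC(C)C[C@@H]1C[C@H](Cl)C[C@H](CC(C)C)O1` and compound 2 `CC(C)C[C@H]1C[C@@H](Cl)C[C@@H](c2ccccc2)O1` share the same core; compound 2 carries a phenyl ring where compound 1 carries a second isobutyl chain. In a functional assay on A2780 cells (Homo sapiens) for antiproliferative activity (a higher number here means a weaker inhibitor of growth, a lower number a stronger inhibitor of growth), compound 1 gives 90000 nM, and compound 2 gives 35000 nM. Compound 2 thus stands at the lower of the two numbers, and its gap to compound 1 lies beyond the scatter. Compound 3 `COc1ccc([C@@H]2C[C@H](Cl)C[C@H](CC(C)C)O2)cc1` is not yet measured. It differs from compound 2 by methoxy in place of hydrogen on an aromatic carbon. Among the measured compounds shown here, no measured pair shows what this change does, so the size of the step rests on judgement alone: a small move toward a lower number, or none beyond the scatter, is expected. For compound 3 in this assay the value is estimated at 25000 nM, within 8000 nM to 80000 nM. On this estimate the expected step is a 1.4-fold lower number from compound 2 to compound 3 (0.15 log units; within the scatter).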

Compound 3, concentration for total growth inhibition: 57000 nM
Compound 3: the middle estimate sits 2.3-fold (0.36 log units) below what was measured, and the stated range covers the measured number.
By their numbers in this assay, from the lowest: compounds 2, 3 and 1 (each within the scatter of the next, the first and the last beyond it).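

Methoxy in place of hydrogen on the aromatic ring, para to a large group, gives a 1.6-fold higher number from compound 2 to compound 3 (0.21 log units; within the scatter) in this assay. Among the compounds shown here, this is the first reading of any substitution on the aryl ring: at this position, a methoxy group with its one hydrogen-bond acceptor brings no shift that can be told from the scatter, in either direction. Nothing at hand bears on the reason for the size of this step.

Methoxy is the only substituent on the ring among these compounds, so the response of this position to an amine, a carboxylic acid or a longer alkoxy chain remains open. Also open, as far as these compounds go, is whether methoxy elsewhere on the ring would behave the same way.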